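A few compounds are considered here, and "the series" means these few. Any claim that something is new, unique, unknown or untested is made for them only; others in the source may bear on it.

Measured compounds:

Compound 1, `Cc1ccc2c(=O)oc(-c3ccccc3I)nc2c1`: in an assay on isolated protein for inhibition of complement C1r subcomponent (Homo sapiens) (on this read-out lower numbers stand for stronger inhibition and higher numbers for weaker inhibition), compound 1 gives > 62500 nM, a limit of the assay rather than a number.
Compound 2, `COc1ccc2nc(-c3ccccc3I)oc(=O)c2c1`: in this assay compound 2 gives > 62500 nM, again a limit rather than a number.
Compound 3, `COc1ccc2c(=O)oc(-c3ccccc3I)nc2c1`: in this assay compound 3 gives > 62500 nM, also a limit rather than a number.

Compound 3 therefore stands at the assay limit, and the two further values shown are limits as well, so that the limit of > 62500 nM in this assay, at which 3 of the 3 values shown sit, describes the whole measured set. Among the compounds with values here, the one step between compounds that differ in a single place, a step that the two limits leave unreadable from compound 1 to compound 3, is unreadable, since both of its ends are limits.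

Compound 4, `COc1cc2nc(-c3ccccc3I)oc(=O)c2cc1OC`, differs from compound 3 by methoxy in place of hydrogen on an aromatic carbon. Within the data shown here, no measured step in this assay bears on this change with a readable size; the only comparable change, the methoxy for methyl step from compound 1 to compound 3, leaves no size to draw on. The account thus expects compound 4 to remain at the limit, with the step that the limit leaves unreadable from compound 3 to compound 4 estimated as nothing readable.

Compound 4 is estimated at 100000 nM, within a range from 30000 nM to 400000 nM.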

Compound 4, half-maximal inhibitory concentration: > 62500 nM
Compound 4 gave a limit, no number (the forecaster's own chance of this, stated with the estimate: 85%); the middle value is on the limit's open side.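

The steps from compound 2 and from compound 3 to compound 4 cannot be read in this assay because each of them has a limit at both ends: the limit of > 62500 nM in this assay, at which 4 of the 4 values shown sit. The compounds shown leave open how large any of these changes is, and whether any change to the shared core would give a readable value.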